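Anilino series: cytotoxicity notes toward compound 3

The source may report more compounds than this note shows. Statements on the series, on what has been measured and on what is new or still open speak of the compounds shown alone.

compound 1 `Fc1cccc(-c2nc(Nc3ccccc3)c3cc(F)ccc3n2)c1`: 47800 nM
compound 2 `Fc1cccc(-c2nc(Nc3ccccc3F)c3cc(F)ccc3n2)c1`: > 50000 nM

In a functional assay on MDA-MB-231 cells (Homo sapiens) for cytotoxicity, read by MTT assay, with a stated time of 48 h (a higher number here means a weaker inhibitor, a lower number a stronger inhibitor), compound 1 gives 47800 nM. For compound 2 the assay reports only a limit, > 50000 nM, which is the limit of > 50000 nM in this assay, at which 1 of the 2 values shown sits. Compound 2 therefore stands at a limit of this assay rather than at a number of its own. Among the compounds with values here, the single measured step, an at least 1.0-fold higher number from compound 1 to compound 2 (0.01 log units; that floor lies within the scatter), lies within the scatter and shows only that fluoro in place of hydrogen on an aromatic carbon left the weak inhibition where it was. Compound 3 `Fc1cccc(-c2nc(Nc3ccc(Cl)cc3)c3cc(F)ccc3n2)c1` differs from compound 2 by 4-chlorophenyl in place of 2-fluorophenyl on a nitrogen on an aromatic ring. Within the data shown here, no measured step covers this change, so the expectation for this assay rests on the weak standing of both measured compounds: no step beyond the scatter, an at least 1.1-fold lower number from compound 2 to compound 3 (0.04 log units; that floor lies within the scatter). Compound 3 is expected to give 45000 nM, estimated between 20000 nM and 100000 nM, with a fair chance that only a limit is reported.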

Compound 3, half-maximal inhibitory concentration: > 50000 nM
Compound 3 gave a limit, no number; the forecaster's own chance of this, stated with the estimate: 45%; middle value at least 1.1-fold (0.04 log units) away from the limit.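

In this assay compound 3 also returns only a limit, > 50000 nM, and not a number. A 4-chlorophenyl group where the plain phenyl group stood gives an at least 1.0-fold higher number from compound 1 to compound 3 (0.01 log units; that floor lies within the scatter), so a halogen on the phenyl group on this nitrogen has now twice failed to yield any readable gain in inhibition, with the 4-chlorophenyl change behaving here like the earlier fluoro change. The direct step from 2-fluorophenyl to 4-chlorophenyl cannot be read, and most of the series now rests on one limit rather than on numbers: the limit of > 50000 nM in this assay, at which 2 of the 3 values shown sit.

From the compounds shown here alone, what numbers compound 2 and compound 3 would carry stays open, so the two halogen changes cannot be ranked against each other. Also open, going by these compounds, is whether an amine or a carboxylic acid on that phenyl group would bring a value that can be read.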